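Toward a secondary amine in a sulfonamide series

A few compounds are considered here, and "the series" means these few. Any claim that something is new, unique, unknown or untested is made for them only; others in the source may bear on it.

For the measured compounds named here, the two compounds measured so far share a sulfonamide bearing trifluoromethyl groups, joined through a saturated chain to a benzylic amine. Compound 1 `O=S(=O)(NCCCNCc1ccc(C(F)(F)F)cc1)c1cc(C(F)(F)F)cc(C(F)(F)F)c1` carries a secondary amine, and in a functional assay on HT-29 cells (Homo sapiens) for inhibition, read by MTT assay, with a stated time of 72 h (a higher number here means a weaker inhibitor of growth, a lower number a stronger inhibitor of growth), compound 1 gives 2900 nM. Compound 2 `CN(CCCNS(=O)(=O)c1cc(C(F)(F)F)cc(C(F)(F)F)c1)Cc1ccccc1` has a methyl on that amine and a plain benzyl group. In this assay compound 2 gives > 50000 nM, which is a limit of the assay rather than a number. Compound 2 therefore sits at the weak end of the two values shown, at the limit of > 50000 nM in this assay, at which 1 of the 2 values shown sits.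

Compound 3 `COc1ccc(CNCCCNS(=O)(=O)c2cc(C(F)(F)F)cc(C(F)(F)F)c2)cc1` has not yet been measured. The change from compound 2 to compound 3 is (4-methoxybenzyl)amino in place of benzyl(methyl)amino on a saturated chain carbon, three bonds along the chain from a sulfonamide nitrogen. Going by the values given here, no step between measured compounds is at hand, so the expectation rests on the two values alone: compound 1, which also carries a secondary amine with a substituted benzyl, gives a number rather than a limit. The account expects a sizeable step toward stronger growth inhibition, an at least 10-fold lower number from compound 2 to compound 3 (1.00 log units; beyond the scatter), well beyond the scatter. Compound 3 is estimated at 5000 nM, with a range from 1500 nM to 20000 nM.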

Compound 3, concentration for 50% growth inhibition: 2900 nM
For compound 3 the middle estimate is 1.7-fold (0.24 log units) above the measured one, and the stated range covers the measured number.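

In this assay, (4-methoxybenzyl)amino in place of benzyl(methyl)amino on a saturated chain carbon, three bonds along the chain from a sulfonamide nitrogen, gives an at least 17-fold lower number from compound 2 to compound 3 (1.23 log units; beyond the scatter), so this place in the series can carry a large change in growth inhibition, something the two earlier compounds, which differ in more than one place, could not show as a step of its own. The size of that step has only a lower bound, since compound 2 holds a limit of the assay and not a number: the limit of > 50000 nM in this assay, at which 1 of the 3 values shown sits. With methoxy in place of trifluoromethyl on an aromatic carbon there is no change at the digits printed from compound 1 to compound 3 (within the scatter), so in this assay these two groups are not told apart at that carbon, and the gain over compound 2 appears with either of them.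

The compounds shown do not separate the methyl leaving the amine from the methoxy entering the ring, as both belong to the one exchange that leads to compound 3. They also leave open how a plain benzylamino group, or a longer chain between the two nitrogens, would read in this assay.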